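The compounds below may be only part of what the source reports. "The series", "measured", "known", "first", "only" and "open" are said of these compounds alone.

Measured in a toxicity assay on MT4 cells (Homo sapiens) for cytotoxicity, read by MTT assay; on this read-out higher numbers stand for lower toxicity in this test and lower numbers for higher toxicity in this test:

- compound 1 `Cc1cc(-c2ccccc2F)cc(C)c1Oc1cc(N)nc(Nc2ccc(C#N)cc2)n1` gives 29300 nM
- compound 2 `Cc1cc(-c2ccccc2Cl)cc(C)c1Oc1cc(N)nc(Nc2ccc(C#N)cc2)n1` gives 25100 nM
- compound 3 `Cc1cccc(-c2cc(C)c(Oc3cc(N)nc(Nc4ccc(C#N)cc4)n3)c(C)c2)c1` gives 27600 nM

These three values lie within the usual scatter of one another, so compound 3 cannot be ranked against compound 1 or compound 2. Compound 4 `COc1cccc(-c2cc(C)c(Oc3cc(N)nc(Nc4ccc(C#N)cc4)n3)c(C)c2)c1` is not yet measured. It carries methoxy in place of methyl on an aromatic carbon, meta to a large group (methoxy in place of methyl on an aromatic carbon).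

Three measured steps change the same outer aromatic group: a 1.1-fold lower number from compound 1 to compound 3 (0.03 log units; within the scatter), a 1.1-fold higher number from compound 2 to compound 3 (0.04 log units; within the scatter) and a 1.2-fold lower number from compound 1 to compound 2 (0.07 log units; within the scatter). All of them stay within the scatter. None of them tests a methoxy group, so they offer only indirect guidance. On this evidence, no change beyond the scatter is expected in this assay. The estimated change is a 1.0-fold lower number from compound 3 to compound 4 (0.01 log units; within the scatter). Compound 4 is expected to give about 27000 nM, with an estimated range from 14000 nM to 50000 nM.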

Compound 4, half-maximal cytotoxic concentration: 19300 nM
The estimate for compound 4 lay 1.4-fold (0.15 log units) above the measured number; measured number inside the range.
By their numbers in this assay, from the lowest: compounds 4, 2, 3 and 1 (each within the scatter of the next).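

Placing methoxy on this aromatic carbon, meta to a large group, gives the first direct test of an oxygen-linked group here: in this assay the swap from methyl to methoxy gives a 1.4-fold lower number from compound 3 to compound 4 (0.16 log units; within the scatter). The two wider swaps of the whole aromatic group, a 1.3-fold lower number from compound 2 to compound 4 (0.11 log units; within the scatter) and a 1.5-fold lower number from compound 1 to compound 4 (0.18 log units; within the scatter), also stay inside the scatter, so compound 4 cannot be ranked against the other three, and on these four compounds this position tolerates methoxy, methyl and the two halogen-bearing phenyl groups without a clear change in this read-out. No supporting measurement bears on what lies behind these small differences.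

Still open, as far as these compounds go, is whether an amine, a carboxylic acid or a longer chain such as ethoxy at this position would stay within the scatter. Also open, from the compounds shown here alone, is how methoxy would read elsewhere on this ring.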